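Cyano in place of trifluoromethyl: expected cytotoxicity

The source may hold more compounds than are shown below. What is called first, only, known or untested is meant among the compounds shown, and "the series" means these compounds.

Compound 1 `CC(=O)N1CCC(C(=O)N(CCCN2CCC(CNC(=O)c3cnccn3)CC2)c2ccc(C)c(Cl)c2)CC1` gives only a limit in an ADME assay (Homo sapiens) for cytotoxicity (a lower number here means that less compound is tolerated, a higher number that more compound is tolerated), > 52400 nM.
Compound 2 `CC(=O)N1CCC(C(=O)N(CCCN2CCN(Cc3ccc(C(F)(F)F)cc3)CC2)c2ccc(C)c(Cl)c2)CC1` gives 30500 nM in this assay.
Compound 3 `CC(=O)N1CCC(C(=O)N(CCCN2CCC(CNc3ncccn3)CC2)c2ccc(C)c(Cl)c2)CC1` gives only a limit in this assay, > 55100 nM.

For the measured compounds named here, compound 2 thus stands as the only real number among the three values; the other two are limits. Compound 4 `CC(=O)N1CCC(C(=O)N(CCCN2CCN(Cc3ccc(C#N)cc3)CC2)c2ccc(C)c(Cl)c2)CC1` differs from it by cyano in place of trifluoromethyl on an aromatic carbon. Going by the values given here, the single measured step, a step that the two limits leave unreadable from compound 1 to compound 3, sits at a different place and is unreadable between two limits, so no measured step bears on the change from trifluoromethyl to cyano. No step beyond the usual scatter is therefore expected in this assay, and the estimated step is a 1.0-fold lower number from compound 2 to compound 4 (0.01 log units; within the scatter). Compound 4 is expected to give about 30000 nM, with a range from 14000 nM to 55000 nM.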

Compound 4, half-maximal cytotoxic concentration: > 100000 nM
Compound 4 gave a limit, no number; the forecaster's own chance of this, stated with the estimate: 30%; middle value at least 3.3-fold (0.52 log units) away from the limit.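

In this assay, cyano in place of trifluoromethyl on the aromatic ring gives an at least 3.2-fold higher number from compound 2 to compound 4 (0.51 log units; beyond the scatter). For the compounds shown here, this shows that the group at this position can change how much compound is tolerated, which the earlier compounds could not show, as the only earlier step cannot be read. That step size is only a minimum, since compound 4 gives a limit rather than a number: the limit of > 100000 nM in this assay, at which 1 of the 4 values shown sits.

Why cyano is better tolerated than trifluoromethyl here stays open. So does whether a methoxy group or a carboxylic acid at this position would behave like either of them.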